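Butyl to ethyl on the amide of compound 3

A few compounds are considered here, and "the series" means these few. Any claim that something is new, unique, unknown or untested is made for them only; others in the source may bear on it.

Three compounds of the series have numbers in a functional assay on Huh-7 cells (Homo sapiens) for antiproliferative activity, read by CCK-8 assay, with a stated time of 72 h; a lower number here means a stronger inhibitor of growth, a higher number a weaker inhibitor of growth. Compound 1 `CCC1C(=O)N(C)c2cnc(Nc3ccc(S(=O)(=O)NCC(C)C)cc3)nc2N1c1ccn(C)n1` gives 8520 nM. Compound 2 `CCCCNC(=O)c1ccc2c(ccn2-c2ncc3c(n2)N(c2ccn(C)n2)C(CC)C(=O)N3C)c1` gives 8670 nM in this assay. Compound 3 `CCCCNC(=O)c1ccc2c(ccn2-c2ncc3c(n2)N(C2CCCC2)[C@H](CC)C(=O)N3C)c1` gives 683 nM in this assay, the lowest of the three numbers; its gaps to compound 1 and to compound 2 both lie beyond the scatter, so compound 3 is the strongest inhibitor of growth among those measured.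

Compound 4 `CCNC(=O)c1ccc2c(ccn2-c2ncc3c(n2)N(C2CCCC2)[C@H](CC)C(=O)N3C)c1` has not yet been measured. It differs from compound 3 in one place: hydrogen in place of ethyl on a saturated chain carbon, two bonds along the chain from an amide-type nitrogen, that is, butyl to ethyl on the amide. Going by the values given here, no two measured compounds differ in a single place, so there is no measured step against which to scale this change, and the expectation rests on the value of compound 3 alone. A shortening of this kind is expected to move the number little, with a slight shift toward a weaker inhibitor of growth as the more likely direction, but not clearly beyond the scatter. Compound 4 is therefore expected to give about 1000 nM in this assay, with a range from 400 nM to 2500 nM. The step this estimate implies, a 1.5-fold higher number from compound 3 to compound 4 (0.17 log units; within the scatter), is expected to stay within the scatter.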

Compound 4, concentration for 50% growth inhibition: 596 nM
Estimate against measurement, compound 4: 1.7-fold (0.22 log units) above; the measured number falls inside the stated range.
By their numbers in this assay, from the lowest: compounds 4 and 3 (each within the scatter of the next); then compounds 1 and 2 (each within the scatter of the next).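

In this assay, going by these compounds alone, the change from butyl to ethyl on the amide gives a 1.1-fold lower number from compound 3 to compound 4 (0.06 log units; within the scatter) and so provides the first single-place step. Removing these two chain carbons leaves the number within the scatter, so the full butyl chain is not needed to keep growth inhibition at this level in this pair. Nothing measured on these compounds bears on the reason for this result.

Going by these compounds, whether this holds for a shorter methyl group, a longer chain such as hexyl, or a chain ending in an amine or a carboxylic acid stays open. On these data alone, the step also rests on one pair with the rest of compound 3 held fixed, so its size on other parts of the series remains unknown.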